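The source may hold more compounds than are shown below. What is called first, only, known or untested is meant among the compounds shown, and "the series" means these compounds.

Compound 1 `Cc1ccc(Cl)cc1Nc1nc(C(F)(F)F)ccc1CNC(=O)C(C)c1ccc(NS(C)(=O)=O)c(F)c1` gives 14 nM in a functional assay on CHO-K1 cells for antagonist activity at transient receptor potential cation channel subfamily V member 1 (Homo sapiens), read by FLIPR; a lower number here means a stronger inhibitor, a higher number a weaker inhibitor; compound 2 `CC(C(=O)NCc1ccc(C(F)(F)F)nc1N1CC=CCC1)c1ccc(NS(C)(=O)=O)c(F)c1` gives 0.3 nM.

Compound 2 holds the lowest of the two numbers; its nearest neighbour is compound 1, separated by a 47-fold lower number from compound 1 to compound 2 (1.67 log units; beyond the scatter). Compound 3 `CC(C(=O)NCc1ccc(C(F)(F)F)nc1N1CCCCC1C)c1ccc(NS(C)(=O)=O)c(F)c1` carries a group of 7 heavy atoms (6 carbon, 1 nitrogen; one six-membered non-aromatic ring with 1 hetero atom) in place of a group of 6 heavy atoms (5 carbon, 1 nitrogen; one six-membered non-aromatic ring with 1 hetero atom), on an aromatic carbon, on an aromatic carbon of a six-membered aromatic ring with 1 nitrogen, next to the ring nitrogen. Among the compounds with values here, the only measured step, from compound 1 to compound 2, swapped a much larger aromatic group at this same carbon and was large; the present change keeps a six-membered non-aromatic ring of similar size, so compound 3 is expected to show a 1.7-fold higher number from compound 2 to compound 3 (0.22 log units; within the scatter), within the scatter. Compound 3 is estimated at 0.5 nM, in a range from 0.15 nM to 2 nM.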

Compound 3, inhibition constant: 2.9 nM
Beside the measured number, compound 3's estimate is 5.8-fold (0.76 log units) below it; the measured number lies above the stated range.
By their numbers in this assay, from the lowest: compound 2; then compound 3; then compound 1.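

In this assay, this position proves sensitive to more than ring size: 2-methylpiperidin-1-yl, a six-membered non-aromatic ring like the group it replaces, still gives a clear loss (a 9.7-fold higher number from compound 2 to compound 3 (0.99 log units; beyond the scatter)). It nonetheless retains an advantage over (5-chloro-2-methylphenyl)amino (a 4.8-fold lower number from compound 1 to compound 3 (0.68 log units; beyond the scatter)). Nothing available explains the loss.

The step removes a double bond and adds a methyl group together, so the compounds shown do not tell which of the two matters. Unsubstituted piperidin-1-yl would separate them, while the effect of morpholin-4-yl at this carbon also remains open.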